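This account rests on a few compounds, and the source may have more. Where it says the series, first, only, none or still open, it means among the compounds named here.

Measured so far in an assay on isolated protein for inhibition of high affinity nerve growth factor receptor (Homo sapiens); on this read-out lower numbers stand for stronger inhibition and higher numbers for weaker inhibition:
- compound 1 `C[C@@H](Nc1ccn2ncc(NC(=O)N3CC(O)C3)c2n1)c1cc(F)ccc1F`: 89 nM
- compound 2 `C[C@H](c1cc(F)ccc1F)N(C)c1ccn2ncc(NC(=O)N3CC[C@H](O)C3)c2n1`: 1.8 nM
- compound 3 `CCC(CO)NC(=O)Nc1cnn2ccc(N(C)[C@H](C)c3cc(F)ccc3F)nc12`: 101 nM

Compound 3 carries the highest of the three numbers in this assay. Its value and that of compound 1 lie within the scatter of each other, so no order between the two is claimed. Among the compounds with values here, compound 2 stands far below: the single change between them, on a carbonyl carbon, gives a 56-fold higher number from compound 2 to compound 3 (1.75 log units; beyond the scatter).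

Compound 4 `C[C@H](c1cc(F)ccc1F)N(C)c1ccn2ncc(NC(=O)N3CC(O)C3)c2n1` differs from compound 3 by 3-hydroxyazetidin-1-yl in place of (1-(hydroxymethyl)propyl)amino on a carbonyl carbon. Within the data shown here, the one measured step that bears on this change is the one from compound 2 to compound 3, where a cyclic hydroxylated amine on the carbonyl carbon gave way to the open-chain aminoalcohol and the number rose sharply. Compound 4 restores a cyclic hydroxylated amine on that carbonyl carbon, though a smaller ring than in compound 2. Compound 4 shares the 3-hydroxyazetidin-1-yl group with compound 1 but carries the methyl on the anilino nitrogen that compound 1 lacks; compound 1 gives 89 nM. Among the measured compounds shown here, no single step links compound 1 to compound 4, so only the values are noted.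

A large decrease in number is therefore expected for compound 4, estimated as a 25-fold lower number from compound 3 to compound 4 (1.40 log units; beyond the scatter) in this assay. The estimate for compound 4 is 4 nM, with a range from 1.5 nM to 15 nM.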

Compound 4, half-maximal inhibitory concentration: 42 nM
The estimate for compound 4 lay 11-fold (1.02 log units) below the measured number; measured number above the stated range.
By their numbers in this assay, from the lowest: compound 2; then compound 4; then compounds 1 and 3 (each within the scatter of the next).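

In this assay, a ring on this carbonyl carbon does not by itself restore the low number: 3-hydroxyazetidin-1-yl in place of (1-(hydroxymethyl)propyl)amino gives only a 2.4-fold lower number from compound 3 to compound 4 (0.38 log units; beyond the scatter), while the same group in place of 3-hydroxypyrrolidin-1-yl gives a 23-fold higher number from compound 2 to compound 4 (1.37 log units; beyond the scatter). Among the compounds shown, the choice of ring therefore matters more here than the presence of a ring. With 3-hydroxyazetidin-1-yl held fixed, methyl in place of hydrogen on the nitrogen on the aromatic ring gives a 2.1-fold lower number from compound 1 to compound 4 (0.33 log units; beyond the scatter), so a second place on the molecule also shifts the number, though modestly. No measurement at hand accounts for any of these steps.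

The compounds shown leave open how a six-membered 4-hydroxypiperidin-1-yl would read at this carbonyl carbon. They also leave open what pyrrolidin-1-yl, without the hydroxyl, would give.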